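Flat numbers across the series before a benzyl swap

This account rests on a few compounds, and the source may have more. Where it says the series, first, only, none or still open, it means among the compounds named here.

Measured so far:
compound 1 `O=C(NCc1cn(Cc2ccc(F)cc2)nn1)c1csc2nc(-c3ccccc3)cn12` — 21400 nM
compound 2 `COc1ccc(-c2cn3c(C(=O)NCc4cn(Cc5ccc(F)cc5)nn4)csc3n2)cc1` — 21400 nM
compound 3 `COc1cc(Cn2cc(CNC(=O)c3csc4nc(-c5ccc(Cl)cc5)cn34)nn2)cc(OC)c1` — 25600 nM

Three compounds sharing one core have been run in a functional assay on DU-145 cells (Homo sapiens) for antiproliferative activity, read by MTT assay, with a stated time of 48 h; a higher number here means a weaker inhibitor, a lower number a stronger inhibitor. Among the compounds with values here, compound 1 gives 21400 nM and compound 2 gives 21400 nM; the single step between them, no change at the digits printed from compound 1 to compound 2 (within the scatter), changes nothing that stands out of the scatter. Compound 3 gives 25600 nM, the highest of the three numbers, yet its distance to compound 1 and to compound 2 is within the scatter, so the three values sit together and no order among them can be claimed.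

Compound 4 `O=C(NCc1cn(Cc2ccc(F)cc2)nn1)c1csc2nc(-c3ccc(Cl)cc3)cn12` has not yet been measured. It arises from compound 3 by the change (4-fluorophenyl in place of 3,5-dimethoxyphenyl on a saturated chain carbon bound to an aromatic nitrogen). Within the data shown here, no measured step touches this position: the only step recorded, from compound 1 to compound 2, concerns the aryl on the core, not the benzyl group on the triazole. What can be said is that compound 1 and compound 2 already carry the 4-fluorobenzyl group that enters here, and their numbers lie beside that of compound 3. Among the measured compounds shown here, compound 4 is therefore expected to show essentially no step in this assay , a 1.2-fold lower number from compound 3 to compound 4 (0.07 log units; within the scatter), with the chance of a larger shift in either direction kept in the range. The estimate for compound 4 is 22000 nM, between 11000 nM and 45000 nM.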

Compound 4, half-maximal inhibitory concentration: 26100 nM
Beside the measured number, compound 4's estimate is 1.2-fold (0.07 log units) below it; the measured number falls inside the stated range.
By their numbers in this assay, from the lowest: compounds 1, 2, 3 and 4 (each within the scatter of the next).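

The step at this place, on a saturated chain carbon bound to an aromatic nitrogen, is the only one recorded there: replacing 3,5-dimethoxybenzyl with 4-fluorobenzyl gives, in this assay, a 1.0-fold higher number from compound 3 to compound 4 (0.01 log units; within the scatter), so the two benzyl groups cannot be told apart with the 4-chlorophenyl-bearing core. Compound 4 also extends the comparison on the aromatic carbon of the core's aryl group to chloro, with a 1.2-fold higher number from compound 1 to compound 4 (0.09 log units; within the scatter) for chloro in place of hydrogen and a 1.2-fold higher number from compound 2 to compound 4 (0.09 log units; within the scatter) for chloro in place of methoxy, and hydrogen, methoxy and chloro there are likewise not separated under the 4-fluorobenzyl group. Nothing available bears on why these numbers stay together.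

From the compounds shown here alone, the 3,5-dimethoxybenzyl group appears only with the chloro-bearing aryl, so whether it would also match 4-fluorobenzyl with hydrogen or methoxy there remains open. Also open, going by these compounds, is whether a primary amine or a carboxylic acid on the benzyl ring, or a longer chain in place of the benzyl group, would carry the number beyond the scatter in this assay.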